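This account rests on a few compounds, and the source may have more. Where it says the series, first, only, none or still open, it means among the compounds named here.

In an in vitro functional assay on HEK285-7 cells for antagonist activity at prostaglandin D2 receptor 2 (Homo sapiens), read by BRET and beta-arrestin recruitment (a higher number here means a weaker inhibitor, a lower number a stronger inhibitor), compound 1, whose structure is `O=C(O)Cc1sc(C(Cc2ccccc2)c2ccccc2)nc1-c1ccc(Cl)cc1`, gives 510 nM. Compound 2, with the structure `NS(=O)(=O)c1ccc(-c2nc(C(c3ccc(F)cc3)c3ccc(F)cc3)sc2CC(=O)O)cc1`, is built on the same core but carries different groups at both ends. For compound 2 this assay reports only > 100000 nM, which is a limit of the assay and not a measured number. Compound 2 therefore sits at the limit of > 100000 nM in this assay, at which 1 of the 2 values shown sits. Compound 3, with the structure `Cc1cc(-c2nc(C(c3ccc(F)cc3)c3ccc(F)cc3)sc2CC(=O)O)cnc1N`, differs from compound 2 in one place, as 6-amino-5-methylpyridin-3-yl in place of 4-sulfamoylphenyl on an aromatic carbon. For the measured compounds named here, no pair of measured compounds differing in a single place is available, so the size of this step cannot be read from any measured example. The step is expected to run toward stronger inhibition, an at least 3.3-fold lower number from compound 2 to compound 3 (0.52 log units; beyond the scatter), but with wide uncertainty. The estimate for compound 3 is 30000 nM, with a range from 3000 nM to 300000 nM.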

Compound 3, half-maximal inhibitory concentration: > 100000 nM
Compound 3: no number, only a limit; the forecaster's own chance of this, stated with the estimate: 40%; middle value at least 3.3-fold (0.52 log units) from the limit.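

No step can be read between compound 2 and compound 3, because each gives only a limit and not a number: the limit of > 100000 nM in this assay, at which 2 of the 3 values shown sit.

The compounds shown leave open whether 4-sulfamoylphenyl or 6-amino-5-methylpyridin-3-yl gives the stronger inhibitor in this assay.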